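The compounds below may be only part of what the source reports. "The series", "measured", "known", "first", "only" and "open" are said of these compounds alone.

Of the compounds shown here, three sharing one core have been tested in an ADME assay on HeLa cells (Homo sapiens) for cytotoxicity, read by resazurin assay, with a stated time of 2 days; on this read-out higher numbers stand for weaker inhibition and lower numbers for stronger inhibition. Compound 1 (`Cc1ccc(/C=C/c2ncc([N+](=O)[O-])n2C)cc1`) gives > 100000 nM which is a limit and not a number. Compound 2 (`Cn1c([N+](=O)[O-])cnc1/C=C/c1ccccc1Cl`) gives > 100000 nM which is also a limit. Within the data shown here, compound 3 (`Cn1c([N+](=O)[O-])cnc1/C=C/c1ccc(Cl)cc1`) gives 91200 nM as the only actual number in the set. The other two results are limits (the limit of > 100000 nM in this assay, at which 2 of the 3 values shown sit).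

Compound 4 (`Cn1c([N+](=O)[O-])cnc1/C=C/c1ccc(Cl)cc1Cl`) differs from compound 3 in one place (chloro in place of hydrogen on an aromatic carbon): chloro in place of hydrogen on an aromatic carbon, ortho to a large group and meta to a chloro group. Among the measured compounds shown here, only one measured step bears on this, and only loosely, since there chloro takes the place of methyl rather than hydrogen: an at least 1.0-fold lower number from compound 1 to compound 3 (0.04 log units; that floor lies within the scatter) is all that it shows. No step beyond the scatter is therefore expected in this assay and the result may again be only a limit. The expected step is a 1.2-fold lower number from compound 3 to compound 4 (0.08 log units; within the scatter) and no larger. Compound 4 is estimated at 75000 nM (expected range 35000 nM to 100000 nM).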

Compound 4, half-maximal inhibitory concentration: > 100000 nM
Compound 4: no number, only a limit (the forecaster's own chance of this, stated with the estimate: 35%); middle value at least 1.3-fold (0.12 log units) from the limit.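

In this assay, chloro in place of hydrogen on an aromatic carbon, ortho to a large group and meta to a chloro group, gives an at least 1.0-fold higher number from compound 3 to compound 4 (0.04 log units; that floor lies within the scatter), so this second chloro group brings no change that can be told from the scatter. The step from compound 2 to compound 4 cannot be read, as both values are limits. Compound 4 also gives only a limit, so the series now sits almost entirely at the edge of what this read-out reports: the limit of > 100000 nM in this assay, at which 3 of the 4 values shown sit.

On these data alone, how far compound 4 actually lies from compound 3 stays open, as a limit gives no number to compare. Also open, as far as these compounds go, is whether an amine, a carboxylic acid or a longer chain at this place on the ring would give a number clearly lower than that of compound 3.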